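A few compounds are considered here, and "the series" means these few. Any claim that something is new, unique, unknown or untested is made for them only; others in the source may bear on it.

Compound 1 `Cc1nccn1-c1csc(Nc2cccc(Br)c2)n1` was tested in a functional assay on RKO cells (Homo sapiens) for cytotoxicity, read by resazurin assay, with a stated time of 72 h; a lower number here means a stronger inhibitor, a higher number a weaker inhibitor. In this assay compound 1 reaches only the limit of the assay, > 100000 nM. Compound 2 `Cc1cn(-c2csc(Nc3cccc(Br)c3)n2)c(C)n1` differs from compound 1 by methyl in place of hydrogen on an aromatic carbon. In this assay compound 2 likewise gives only a limit, > 100000 nM. The step that the two limits leave unreadable from compound 1 to compound 2 is not readable because of the limit of > 100000 nM in this assay, at which 3 of the 3 values shown sit.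

Compound 3 `Cc1ccc(Nc2nc(-n3ccnc3C)cs2)cc1` has another core; how the core of compound 3 differs from the core of compound 1 is not broken down here. In this assay compound 3 gives only a limit, > 100000 nM.

Compound 4 `Cc1ccc(Nc2nc(-n3cc(C)nc3C)cs2)cc1` has not yet been measured in this assay. It differs from compound 3 by methyl in place of hydrogen on an aromatic carbon, the same change as from compound 1 to compound 2, at a place described in the same words. The step the author expects from compound 3 to compound 4 is a step that the limit leaves unreadable from compound 3 to compound 4, an expectation that rests on the pair compound 1 and compound 2, whose step that the two limits leave unreadable from compound 1 to compound 2 was itself not readable because of the limit of > 100000 nM in this assay, at which 3 of the 3 values shown sit. For compound 4 the estimate in this assay is 150000 nM, expected to lie between 60000 nM and 400000 nM, and most likely to be reported again only as a limit.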

Compound 4, half-maximal inhibitory concentration: > 100000 nM
Compound 4: no number, only a limit (the forecaster's own chance of this, stated with the estimate: 85%); the middle value does not contradict the limit.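

Going by these compounds alone, compound 4, like compound 3, gives only a limit in this assay, and no step between the two can be read because both sit at that limit: the limit of > 100000 nM in this assay, at which 4 of the 4 values shown sit.

The compounds shown leave open whether methyl in place of hydrogen on an aromatic carbon has any effect in this assay, and how compound 1 to compound 4 would order.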